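Positional methoxy isomer on the cyclopropane diamide aryl cap

This account rests on a few compounds, and the source may have more. Where it says the series, first, only, none or still open, it means among the compounds named here.

Measured compounds in a functional assay on A549 cells (Homo sapiens) for inhibition, read by CCK-8 assay, with a stated time of 72 h, tested at 1 uM; a higher number here means more inhibition of growth at the concentration tested, a lower number less inhibition of growth:
compound 1 `COc1ccc(NC(=O)C2(C(=O)Nc3ccc(Nc4ncc5cc(C(=O)N(C)C)n(C6CCCC6)c5n4)cc3)CC2)cc1` gives 74.4%
compound 2 `CN(C)C(=O)c1cc2cnc(Nc3ccc(NC(=O)C4(C(=O)Nc5cccc(C#N)c5)CC4)cc3)nc2n1C1CCCC1` gives 70.8%
compound 3 `CN(C)C(=O)c1cc2cnc(Nc3ccc(NC(=O)C4(C(=O)Nc5cccc(C(F)(F)F)c5)CC4)cc3)nc2n1C1CCCC1` gives 15.7%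

Compound 1 stands at the top of the three numbers recorded in this assay; compound 2 sits with it, the two differing only by a number 3.6 percentage points lower from compound 1 to compound 2 (within the scatter), while compound 3 lies far beneath both, by a number 58.7 percentage points lower from compound 1 to compound 3 (beyond the scatter) and by a number 55.1 percentage points lower from compound 2 to compound 3 (beyond the scatter).

Compound 4 `COc1cccc(NC(=O)C2(C(=O)Nc3ccc(Nc4ncc5cc(C(=O)N(C)C)n(C6CCCC6)c5n4)cc3)CC2)c1` has not been measured. It differs from compound 1 only in the position of the methoxy group on the aryl cap of the cyclopropane diamide: 3-methoxyphenyl in place of 4-methoxyphenyl on an amide-type nitrogen

For the measured compounds named here, no measured step moves a methoxy group from one position to another, so the bearing of the three recorded steps is indirect. They show that a 3-substituted phenyl on the same amide-type nitrogen can either hold the inhibition of compound 1, as with the cyano in a number 3.6 percentage points lower from compound 1 to compound 2 (within the scatter), or lose most of it, as with the trifluoromethyl in a number 58.7 percentage points lower from compound 1 to compound 3 (beyond the scatter). Whether 3-methoxyphenyl behaves like the former or the latter cannot be read from the data, so the expected step in this assay is a modest loss, a number 19.4 percentage points lower from compound 1 to compound 4 (beyond the scatter), with a wide band around it. Compound 4 is therefore estimated at 55%, expected to fall between 15% and 80%.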

Compound 4, percent growth inhibition at one concentration: 77.2%
Compound 4: the middle estimate sits 22.2 percentage points below what was measured; measured number inside the range.
By their numbers in this assay, from the lowest: compound 3; then compounds 2, 1 and 4 (each within the scatter of the next).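

In this assay the methoxy group can sit in either form of the cap: replacing 4-methoxyphenyl with 3-methoxyphenyl on the amide-type nitrogen gives a number 2.8 percentage points higher from compound 1 to compound 4 (within the scatter), so this change leaves the inhibition of growth unchanged at the concentration tested. Compound 4 also shows that the loss in compound 3 does not follow from a 3-substituted phenyl as such, since methoxy and cyano read alike, with a number 6.4 percentage points higher from compound 2 to compound 4 (within the scatter), whereas methoxy in place of trifluoromethyl gives a number 61.5 percentage points higher from compound 3 to compound 4 (beyond the scatter), leaving compound 3 as the one exception among these 3-substituted caps. No available measurement accounts for the separation of trifluoromethyl from methoxy and cyano.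

From the compounds shown here alone, it remains open whether an amine, a carboxylic acid or a longer chain such as ethoxy on the same phenyl would read with compounds 1, 2 and 4 or fall with compound 3. Also open, going by these compounds, is whether compounds 1, 2 and 4, alike at the one concentration used in this assay, would stay together across a range of concentrations.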